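The compounds below may be only part of what the source reports. "The series", "measured", "known", "first", "only" and "open" are said of these compounds alone.

Values in a functional assay on RCC4 cells (Homo sapiens) for antiproliferative activity, read by XTT assay, with a stated time of 48 h (a higher number here means a weaker inhibitor, a lower number a stronger inhibitor), for the three measured compounds:

compound 1, `CC(=O)OC[C@H]1O[C@@H](n2cc(CN(c3ccc(C#N)cc3)S(C)(=O)=O)nn2)[C@H](OC(C)=O)[C@@H]1OC(C)=O`: 235000 nM
compound 2, `COC(=O)CN(Cc1cn([C@@H]2O[C@H](COC(C)=O)[C@@H](OC(C)=O)[C@H]2OC(C)=O)nn1)S(C)(=O)=O`: 125000 nM
compound 3, `CC(=O)OC[C@H]1O[C@@H](n2cc(CN(c3ccc(C#N)cc3)S(C)(=O)=O)nn2)[C@H](OC(C)=O)[C@@H](OC(C)=O)[C@@H]1OC(C)=O`: 120000 nM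

Compound 1 and compound 2 share one core; compound 3 carries a different core, and the difference between the two cores is not broken down here. Within the first core, one change has been measured: (methoxycarbonyl)methyl in place of 4-cyanophenyl on a sulfonamide nitrogen. In this assay this gave a 1.9-fold lower number from compound 1 to compound 2 (0.27 log units; within the scatter), a step that stays inside the usual scatter. Compound 3 stands close to compound 2 and also inside the scatter of compound 1, so no order among the three can be stated.

Compound 4, `COC(=O)CN(Cc1cn([C@@H]2O[C@H](COC(C)=O)[C@@H](OC(C)=O)[C@H](OC(C)=O)[C@H]2OC(C)=O)nn1)S(C)(=O)=O`, has not yet been measured in this assay. It is made from compound 3 by the same change: (methoxycarbonyl)methyl in place of 4-cyanophenyl on a sulfonamide nitrogen. The place is described in the same words for both pairs, so the change is taken as the same one, now on the core of compound 3.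

The expectation is a 1.5-fold lower number from compound 3 to compound 4 (0.18 log units; within the scatter), because the same change gave a 1.9-fold lower number from compound 1 to compound 2 (0.27 log units; within the scatter) and nothing in the data suggests the second core should answer differently. For the measured compounds named here, only one earlier instance exists, so the range is kept broad. For compound 4 the estimate in this assay is 80000 nM, with a span from 40000 nM to 200000 nM.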

Compound 4, half-maximal inhibitory concentration: > 250000 nM
Compound 4: no number, only a limit; the forecaster's own chance of this, stated with the estimate: 15%; middle value at least 3.1-fold (0.49 log units) away from the limit.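

In this assay compound 4 gives > 250000 nM, which is a limit of the assay and not a number. Placing (methoxycarbonyl)methyl in place of 4-cyanophenyl on a sulfonamide nitrogen gives an at least 2.0-fold higher number from compound 3 to compound 4 (0.31 log units; beyond the scatter), so within these two pairs the result of the change does not carry over from one core to the other: the same change on two cores in this assay, a 1.9-fold lower number (0.27 log units; within the scatter) from compound 1 to compound 2 and an at least 2.0-fold higher number (0.31 log units; beyond the scatter) from compound 3 to compound 4, at least 3.9-fold (0.59 log units) apart, beyond the scatter of two such steps. This shows that the outcome of the change differs between the two cores, but it does not show which part of the cores accounts for the difference, and the full size of the new step stays unknown: the limit of > 250000 nM in this assay, at which 1 of the 4 values shown sits.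

Open, on these data alone, is whether the gap between the cores is particular to this one exchange or would also appear with other groups on the sulfonamide nitrogen, such as a carboxylic acid, an amine or a longer chain. Also open is how each core would read with free hydroxyl groups in place of its acetyl esters, since every compound shown carries those esters.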